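Amide to urea on a pyrazole-linked aryl series

The source may report more compounds than this note shows. Statements on the series, on what has been measured and on what is new or still open speak of the compounds shown alone.

Compound 1 `COc1cc(-c2nn(-c3cccc(NC(=O)c4ccc(Cl)c(C(F)(F)F)c4)c3)cc2-c2ccncc2)ccc1Cl` — 2700 nM
Compound 2 `O=C(Nc1cccc(-n2cc(-c3ccncc3)c(-c3ccc(Cl)c(O)c3)n2)c1)Nc1cc(C(F)(F)F)cc(C(F)(F)F)c1` — 790 nM
Compound 3 `O=C(Nc1cccc(-n2cc(-c3ccncc3)c(-c3ccc(Cl)c(O)c3)n2)c1)Nc1ccc(Cl)c(C(F)(F)F)c1` — 1400 nM

Of the compounds shown here, three have been tested in a functional assay on A498 cells (Homo sapiens) for inhibition, read by sulforhodamine B assay, with a stated time of 48 h; a higher number here means a weaker inhibitor, a lower number a stronger inhibitor. Compound 1 gives the highest of the three numbers, 2700 nM. Its nearest neighbour is compound 3, whose value of 1400 nM lies within the scatter of compound 1, so no order between the two can be drawn. Compound 2, at 790 nM, lies beyond the scatter from compound 1 and is the lower of the two. Going by the values given here, compounds 2 and 3 both differ from compound 1 in more than one place, so no single step between measured compounds is available.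

Compound 4 `COc1cc(-c2nn(-c3cccc(NC(=O)Nc4ccc(Cl)c(Cl)c4)c3)cc2-c2ccncc2)ccc1Cl` is the next compound, not yet measured in this assay. It differs from compound 1 in one place: (3,4-dichlorophenyl)amino in place of 4-chloro-3-(trifluoromethyl)phenyl on a carbonyl carbon. The urea-bearing compounds 2 and 3 both gave lower numbers than compound 1, although each also carries a different group on the far ring, so the comparison is not clean. The estimate for compound 4 is therefore a modest step downward from compound 1, a 1.8-fold lower number from compound 1 to compound 4 (0.26 log units; within the scatter), with the possibility that the change is within the scatter. The expected value for compound 4 in this assay is 1500 nM, in a range from 500 nM to 5000 nM.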

Compound 4, half-maximal inhibitory concentration: 1140 nM
Estimate against measurement, compound 4: 1.3-fold (0.12 log units) above; the range from low to high includes it.
By their numbers in this assay, from the lowest: compounds 2, 4, 3 and 1 (each within the scatter of the next, the first and the last beyond it).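

Among the compounds shown, only one comparison in this assay differs in one place: (3,4-dichlorophenyl)amino in place of 4-chloro-3-(trifluoromethyl)phenyl on the carbonyl carbon gives a 2.4-fold lower number from compound 1 to compound 4 (0.37 log units; beyond the scatter). Going by these compounds alone, with the rest of the core held fixed, this shows that the number responds to a change at this position, which the earlier compounds could not show, as compounds 2 and 3 each differ from compound 1 in more than one place. The exchange brings in the amide-type nitrogen and swaps the ring's trifluoromethyl for chlorine in a single step, and no measurement at hand explains the size of the step.

What stays open is how the step divides between these two parts: the compounds shown include neither (4-chloro-3-(trifluoromethyl)phenyl)amino nor plain 3,4-dichlorophenyl on this carbonyl carbon with the core of compound 1, and either one would separate them. Also open, as far as these compounds go, is how this position would respond to an oxygen linker in place of the nitrogen, as in a carbamate, or to an N-methyl group on that nitrogen.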